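The source may report more compounds than this note shows. Statements on the series, on what has been measured and on what is new or still open speak of the compounds shown alone.

Measured so far:
Compound 1 `COc1cc2c(Oc3ccc(NC(=O)N/N=C/c4ccc(C(F)(F)F)cc4)cc3F)ccnc2cc1OCCCN1CCCCC1` gives 660 nM in a functional assay on A549 cells (Homo sapiens) for cytotoxicity, read by MTT assay, with a stated time of 72 h; on this read-out higher numbers stand for weaker inhibition and lower numbers for stronger inhibition.
Compound 2 `COc1ccc(/C=N/NC(=O)Nc2ccc(Oc3ccnc4cc(OCCCN5CCCCC5)c(OC)cc34)c(F)c2)c(OC)c1` gives 1400 nM in this assay.
Compound 3 `C=CCc1cccc(/C=N/NC(=O)Nc2ccc(Oc3ccnc4cc(OCCCN5CCCCC5)c(OC)cc34)c(F)c2)c1OC` gives 250 nM in this assay.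

Compound 1 stands second highest of these three numbers: there is a 2.1-fold higher number from compound 1 to compound 2 (0.33 log units; beyond the scatter), and there is a 2.6-fold lower number from compound 1 to compound 3 (0.42 log units; beyond the scatter); between the other two there is a 5.6-fold lower number from compound 2 to compound 3 (0.75 log units; beyond the scatter). Compound 4 `COc1cc2c(Oc3ccc(NC(=O)N/N=C/c4ccc(C(F)(F)F)cc4)cc3F)ccnc2cc1OCCCN1CCC(C)CC1` differs from compound 1 only by methyl in place of hydrogen on a saturated ring carbon. Going by the values given here, every measured step instead swapped the ring on the carbon double-bonded to nitrogen, so no measured step bears on this change, and there is no basis for expecting a shift beyond the scatter in this assay. Compound 4 is therefore estimated at 650 nM, with a range of 280 nM to 1500 nM, meaning an expected 1.0-fold lower number from compound 1 to compound 4 (0.01 log units; within the scatter).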

Compound 4, half-maximal inhibitory concentration: 650 nM
Compound 4: middle estimate and measured number agree at the digits printed; measured number inside the range.
By their numbers in this assay, from the lowest: compound 3; then compounds 4 and 1 (each within the scatter of the next); then compound 2.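

Unlike the earlier steps, which swapped the ring on the carbon double-bonded to nitrogen, this one changes piperidin-1-yl to 4-methylpiperidin-1-yl. In this assay it gives a 1.0-fold lower number from compound 1 to compound 4 (0.01 log units; within the scatter), so adding this methyl to the saturated ring carbon causes no shift that can be told from the usual scatter. No measured evidence here offers an explanation for this result.

A hydroxyl group, a carboxylic acid or a longer chain at this carbon could behave differently, and the compounds shown do not settle that. Also open, as far as these compounds go, is whether the same methyl would leave the numbers of compound 2 and compound 3 unmoved.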